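Methylsulfanyl in place of isopropyl in compound 1

This account rests on a few compounds, and the source may have more. Where it says the series, first, only, none or still open, it means among the compounds named here.

Compound 1 `COc1cc(/C=C/c2ccc(C(C)C)cc2)cc(OC)c1OC`: 9.8 uM
Compound 2 `COc1cc(/C=C\c2ccc(C(C)(C)C)cc2)cc(OC)c1OC`: 1.02 uM
Compound 3 `COc1cc(/C=C\c2ccc(C(C)C)cc2)cc(OC)c1OC`: 6.6 uM

These three values come from a functional assay on A549 cells (Homo sapiens) for cytotoxicity; on this read-out lower numbers stand for an effect already at smaller amounts and higher numbers for an effect only at larger amounts of compound. Compound 1 gives 9.8 uM and, together with compound 3, forms the upper pair of the three numbers, while compound 2 gives the clearly lower 1.02 uM. The next compound to be tested in this assay is compound 4 `COc1cc(/C=C/c2ccc(SC)cc2)cc(OC)c1OC`, which keeps the core of compound 1 and differs from it in one group: methylsulfanyl in place of isopropyl on an aromatic carbon. In words, methylsulfanyl stands in place of isopropyl on an aromatic carbon.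

Two measured steps offer some guidance. The first, a 1.5-fold lower number from compound 1 to compound 3 (0.17 log units; within the scatter), rests on (the fact that compounds 1 and 3 differ only in the configuration as drawn), so it leaves the group in question untouched and says little about this exchange. The second, a 6.5-fold higher number from compound 2 to compound 3 (0.81 log units; beyond the scatter), is hydrogen in place of methyl on a saturated chain carbon. It shows that a change in this group can go beyond the scatter, but it is a different exchange and gives no firm direction for this one. No step beyond the scatter is therefore expected, and the range is kept wide. The expected change is a 1.2-fold lower number from compound 1 to compound 4 (0.09 log units; within the scatter). The estimate for compound 4 is 8 uM, with an expected range from 2.5 uM to 25 uM.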

Compound 4, concentration for half-maximal effect: 4.7 uM
For compound 4 the middle estimate is 1.7-fold (0.23 log units) above the measured one; low and high end bracket the measured number.
By their numbers in this assay, from the lowest: compound 2; then compounds 4, 3 and 1 (each within the scatter of the next, the first and the last beyond it).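

In this assay, for the compounds shown here, the exchange of isopropyl for methylsulfanyl gives a 2.1-fold lower number from compound 1 to compound 4 (0.32 log units; beyond the scatter), a modest step but one that shows the aromatic carbon carrying this group responds to a change of the group in a compound with the double bond drawn E. The only earlier step beyond the scatter came from two compounds with the double bond drawn Z, and it altered a saturated chain rather than replacing the whole group; here the incoming group brings a sulfur and a hydrogen-bond acceptor to that same place, with a smaller number of heavy atoms than isopropyl. The measured compounds give no information on which of these differences lies behind the step.

From the compounds shown here alone, it remains open whether methylsulfanyl would give a similar step with the double bond drawn Z, where compound 3 gives 6.6 uM and compound 2, carrying the larger chain group, gives 1.02 uM. The compounds shown also leave open how methoxy, an amine or a longer sulfur-bearing chain such as ethylsulfanyl would behave at this position on the core of compound 1.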